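A few compounds are considered here, and "the series" means these few. Any claim that something is new, unique, unknown or untested is made for them only; others in the source may bear on it.

Measured compounds:
compound 1 `CN(C)c1ccc(C(=O)Nc2cccc(NC(=O)COc3ccc4c(c3)CCC(=O)N4)c2)cc1` with 9970 nM in an assay on isolated protein for inhibition of Rho-associated protein kinase 2 (Homo sapiens), read by scintillation counting, radiometric assay and 33P incorporation, with a stated time of 40 min, in the presence of a further agent that is not named here; on this read-out higher numbers stand for weaker inhibition and lower numbers for stronger inhibition
compound 2 `CN(C)c1ccc(C(=O)Nc2cccc(NC(=O)COc3ccc4c(c3)OCCC4=O)c2)cc1` with 85 nM in this assay
compound 3 `CCCC(=O)Nc1cccc(NC(=O)COc2ccc3c(=O)ccoc3c2)c1` with 176 nM in this assay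

Compound 3 stands second highest of the three numbers in this assay. Its nearest neighbour is compound 2, whose number is lower by a step beyond the scatter, and its furthest is compound 1, whose number is higher by a step far beyond the scatter. Among the compounds with values here, the only single-point step among the measured compounds is a 120-fold lower number from compound 1 to compound 2 (2.07 log units; beyond the scatter), a change on the oxygen on a saturated carbon, a different place from the one altered here.

Compound 4 `O=C(COc1ccc2c(=O)ccoc2c1)Nc1cccc(NC(=O)c2ccc(F)cc2)c1` differs from compound 3 by 4-fluorophenyl in place of propyl on a carbonyl carbon. Within the data shown here, no measured pair isolates this change; compounds 1 and 2 carry yet another group on that carbonyl carbon and differ from compound 3 elsewhere as well, so their numbers cannot be read as a guide to this step. Compound 3 is therefore taken as the anchor, and a modest step toward a lower number in this assay is expected, a 1.6-fold lower number from compound 3 to compound 4 (0.20 log units; within the scatter), though one not beyond the scatter would also be unsurprising. Compound 4 is estimated at 110 nM, within 35 nM to 350 nM.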

Compound 4, half-maximal inhibitory concentration: 54 nM
Estimate against measurement, compound 4: 2.0-fold (0.31 log units) above; the range from low to high includes it.
By their numbers in this assay, from the lowest: compounds 4 and 2 (each within the scatter of the next); then compound 3; then compound 1.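

In this assay, within the data shown here, 4-fluorophenyl in place of propyl on the carbonyl carbon gives a 3.3-fold lower number from compound 3 to compound 4 (0.51 log units; beyond the scatter), the first reading of a change at this place, since the only earlier single-point step, a 120-fold lower number from compound 1 to compound 2 (2.07 log units; beyond the scatter), lay on the oxygen on a saturated carbon. The entering group brings a six-membered aromatic ring of carbon only where propyl has no ring, and in this one pair the number falls rather than rises. Nothing measured on these compounds speaks to why the number moves with this change.

The compounds shown leave open whether the ring or the fluorine carries the step, which plain phenyl on the same carbonyl carbon would separate. Also open, on these data alone, are how a longer chain or an amine would fare at this place, and whether the step would hold on the core of compound 1 or compound 2.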